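Lengthening the Alkyl Chain on Two Thiazolidine Amide Cores

The compounds below may be only part of what the source reports. "The series", "measured", "known", "first", "only" and "open" are said of these compounds alone.

Measured compounds:
compound 1, `CCCCCCCCCCCCNC(=O)[C@@H]1CSC(c2cc(OC)c(OC)c(OC)c2)N1`, 2400 nM 
compound 2, `CCCCCCCCCCCCCCNC(=O)[C@@H]1CSC(c2cc(OC)c(OC)c(OC)c2)N1`, 1600 nM 
compound 3, `CCCCCCCCCCCCNC(=O)[C@@H]1CSC(c2ccc(NC(C)=O)cc2)N1`, 1200 nM 

In a functional assay on WM164 cells (Homo sapiens) for antiproliferative activity, read by sulforhodamine B assay, with a stated time of 48 h (a lower number here means a stronger inhibitor, a higher number a weaker inhibitor), compound 1 gives 2400 nM and compound 2 gives 1600 nM. The two share a core and differ by ethyl in place of hydrogen on a saturated chain carbon, ten or more bonds along the chain from an amide-type nitrogen; that step reads a 1.5-fold lower number from compound 1 to compound 2 (0.18 log units; within the scatter), so the two numbers cannot be told apart. Compound 3 carries a different core; the difference between its core and the core of compound 1 is not broken down here. In this assay compound 3 gives 1200 nM, which sits within the scatter of both compound 1 and compound 2, so no order among the three can be claimed.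

Compound 4, `CCCCCCCCCCCCCCNC(=O)[C@@H]1CSC(c2ccc(NC(C)=O)cc2)N1`, has not yet been tested in this assay. It differs from compound 3 by ethyl in place of hydrogen on a saturated chain carbon, ten or more bonds along the chain from an amide-type nitrogen, the same change made from compound 1 to compound 2. Since that earlier step was a 1.5-fold lower number from compound 1 to compound 2 (0.18 log units; within the scatter), the change is expected to leave the number close to where compound 3 stands. The expected step is a 1.2-fold lower number from compound 3 to compound 4 (0.08 log units; within the scatter), resting on a 1.5-fold lower number from compound 1 to compound 2 (0.18 log units; within the scatter). Compound 4 is therefore estimated at 1000 nM in this assay, with the range 500 nM to 2200 nM expected to cover most repeats.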

Compound 4, half-maximal inhibitory concentration: 600 nM
For compound 4 the middle estimate is 1.7-fold (0.22 log units) above the measured one; low and high end bracket the measured number.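

In this assay, the same change, ethyl in place of hydrogen on a saturated chain carbon, ten or more bonds along the chain from an amide-type nitrogen, now gives a 2.0-fold lower number from compound 3 to compound 4 (0.30 log units; within the scatter). Set beside the earlier step, the change reads alike on the two cores as far as these data can resolve: the same change on two cores in this assay, a 1.5-fold lower number (0.18 log units; within the scatter) from compound 1 to compound 2 and a 2.0-fold lower number (0.30 log units; within the scatter) from compound 3 to compound 4, 1.3-fold (0.12 log units) apart, within the scatter of two such steps. This shows that nothing here separates the two cores in how they take the change, but it does not establish a real shift in the number on either core, as each step on its own lies within the scatter, and two cores give no assurance about a third.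

The compounds shown leave open whether a longer chain or a shorter chain would move the number beyond the scatter on either core. They also leave open how the number would respond to a chain carrying an amine or a carboxylic acid, and whether the change would carry over to a core with a different group on its aromatic ring, such as a nitrile or a trifluoromethyl.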